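The source may report more compounds than this note shows. Statements on the series, on what has been measured and on what is new or still open speak of the compounds shown alone.

Measured compounds:
- compound 1 `COc1ccc2nc(NC(=O)CNC(=O)c3nn(-c4ccccc4)c(=O)c4ccccc34)sc2c1`: 210 nM
- compound 2 `COc1ccc(-n2nc(C(=O)NCC(=O)Nc3nc4ccc(OC)cc4s3)c3ccccc3c2=O)cc1`: 60 nM

In an assay on L cells for inhibition of Protein-serine O-palmitoleoyltransferase porcupine (Mus musculus), read by reporter gene assay, with a stated time of 24 h (on this read-out higher numbers stand for an effect only at larger amounts of compound and lower numbers for an effect already at smaller amounts), compound 1 gives 210 nM and compound 2 gives 60 nM. Among the compounds with values here, of the two numbers, compound 1 holds the higher one: the single measured step, a 3.5-fold lower number from compound 1 to compound 2 (0.54 log units; beyond the scatter), shows that adding a methoxy group to the phenyl ring attached to the nitrogen of the core lowers the number.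

Compound 3 `O=C(CNC(=O)c1nn(-c2ccccc2)c(=O)c2ccccc12)Nc1nc2ccccc2s1` has not yet been measured. It differs from compound 1 by hydrogen in place of methoxy on an aromatic carbon; in other words the 6-methoxy-1,3-benzothiazol-2-yl end becomes a plain 1,3-benzothiazol-2-yl end. Within the data shown here, no measured step concerns a change at this part of the molecule. Among the measured compounds shown here, the only step on record, a 3.5-fold lower number from compound 1 to compound 2 (0.54 log units; beyond the scatter), describes a methoxy group elsewhere, so it gives no direct guide to what removing this one will do. Taking that step only as a hint that a methoxy group can help, the number for compound 3 is expected to rise slightly or stay within the scatter, as a 1.5-fold higher number from compound 1 to compound 3 (0.18 log units; within the scatter). The estimate for compound 3 in this assay is 320 nM, with a range from 120 nM to 900 nM.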

Compound 3, half-maximal effective concentration: 2600 nM
Beside the measured number, compound 3's estimate is 8.1-fold (0.91 log units) below it; measured number outside the range, above it.
By their numbers in this assay, from the lowest: compound 2; then compound 1; then compound 3.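

In this assay, the 6-methoxy-1,3-benzothiazol-2-yl end proves highly sensitive to a small change: putting hydrogen in place of the methoxy gives a 12-fold higher number from compound 1 to compound 3 (1.09 log units; beyond the scatter) and shows that this one group on the aromatic carbon matters greatly for the number reached by compound 1. Within the data shown here, the only methoxy change known before lay at a different place in the molecule, where the result was a 3.5-fold lower number from compound 1 to compound 2 (0.54 log units; beyond the scatter) and the step was smaller, so a methoxy goes with a lower number at both places, and the effect is the larger one at this end. No measurement offered here explains why this methoxy has such a strong effect.

The compounds shown leave open whether methoxy is specifically required at this carbon, or whether a hydroxyl, a fluorine, an amine or a longer chain such as ethoxy would keep the number low or take it lower still. They also leave open whether removing this methoxy would cost as much in compound 2, which carries a second methoxy group on its phenyl ring.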